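Bromo on the core of compound 1

A few compounds are considered here, and "the series" means these few. Any claim that something is new, unique, unknown or untested is made for them only; others in the source may bear on it.

Going by the values given here, in a functional assay on KM12 cells (Homo sapiens) for antiproliferative activity (on this read-out higher numbers stand for weaker inhibition of growth and lower numbers for stronger inhibition of growth), compound 1 (`COc1ccc(-c2nc3ccccc3s2)cc1OC`) gives 74200 nM as the higher of the two numbers so far. Compound 2 (`COc1ccc(-c2nc3ccc(F)cc3s2)cc1OC`) gives 24100 nM and stands lower. Compound 3 (`COc1ccc(-c2nc3cc(Br)ccc3s2)cc1OC`) has not been measured. Its difference from compound 1 is bromo in place of hydrogen on an aromatic carbon and amounts to bromo in place of hydrogen on an aromatic carbon of a six-membered aromatic ring of carbon only.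

Among the compounds with values here, one measured step bears on this change: a 3.1-fold lower number from compound 1 to compound 2 (0.49 log units; beyond the scatter) for fluoro in place of hydrogen on an aromatic carbon. That step is modest but beyond the scatter. Within the data shown here, no bromo compound has been measured, so this single step is a weak guide and the margin must stay wide. A step of similar modest size towards a lower number, meaning stronger inhibition of growth, is therefore expected. The estimated step is a 2.7-fold lower number from compound 1 to compound 3 (0.42 log units; beyond the scatter) and it is expected to fall short of certainty in direction. In this assay compound 3 is expected at 28000 nM with 9000 nM to 75000 nM as the estimated range.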

Compound 3, concentration for 50% growth inhibition: 65200 nM
Compound 3: the middle estimate sits 2.3-fold (0.37 log units) below what was measured; low and high end bracket the measured number.
By their numbers in this assay, from the lowest: compound 2; then compounds 3 and 1 (each within the scatter of the next).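

In this assay, bromo on this aromatic carbon, meta to a fused ring and para to a fused ring, gives a 1.1-fold lower number from compound 1 to compound 3 (0.06 log units; within the scatter), so this replacement of hydrogen on the core of compound 1 produces no readable shift in growth inhibition. The modest step seen with fluoro therefore does not extend to every halogen placed on this ring: a 3.1-fold lower number from compound 1 to compound 2 (0.49 log units; beyond the scatter) stands beyond the scatter, but compound 2 carries its fluoro on a different ring carbon, so the two steps differ in both the group and its place. Nothing at hand bears on the reason for this outcome.

The compounds shown leave open whether the fluoro step belongs to the group or to its ring carbon, since neither fluoro on the carbon that carries bromo in compound 3 nor bromo on the carbon that carries fluoro in compound 2 appears among them. Also open, from the compounds shown here alone, is whether an amine or a carboxylic acid on the bromo-bearing carbon would move the number beyond the scatter in either direction, or whether this carbon stays as unresponsive as the single bromo result suggests.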